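Allyl ether replacing a carboxypentyl ether on the shared core

The source may hold more compounds than are shown below. What is called first, only, known or untested is meant among the compounds shown, and "the series" means these compounds.

For the measured compounds named here, the three measured members share the core of compound 1 `O=c1c(-c2ccc(O)cc2)coc2cc(OCC(O)CO)ccc12` and differ only in the group on the ring oxygen. In a functional assay on mitochondria (Cricetulus griseus) for inhibition of Monoamine oxidase (Homo sapiens), tested at 9 uM (on this read-out higher numbers stand for a stronger effect at the one concentration tested and lower numbers for a weaker effect), compound 1 gives 95.1%. Compound 2 `O=C(O)CCCCCCOc1ccc2c(=O)c(-c3ccc(O)cc3)coc2c1` gives 94.6%, and compound 3 `O=c1c(-c2ccc(O)cc2)coc2cc(CC3OC(CO)C(O)C(O)C3O)ccc12` gives 0%. Compound 2 thus lies with compound 1 at the upper end of the numbers shown, the two within the scatter of each other, and far from compound 3.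

Compound 4 `C=CCOc1ccc2c(=O)c(-c3ccc(O)cc3)coc2c1` differs from compound 2 by vinyl in place of 5-carboxypentyl on a saturated chain carbon bound to an oxygen on an aromatic ring. Going by the values given here, the one step that bears on this place, a number 0.5 percentage points lower from compound 1 to compound 2 (within the scatter), shows that exchanging the chain on that oxygen left the read-out unchanged. A step of no size beyond the scatter is therefore expected, a number 4.6 percentage points lower from compound 2 to compound 4 (within the scatter). Compound 4 is estimated at 90%, between 70% and 99%.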

Compound 4, a percentage reported as inhibition, at one concentration (the size of the read-out at that concentration, not a potency): 100%
Beside the measured number, compound 4's estimate is 10 percentage points below it; measured number outside the range, above it.
By their numbers in this assay, from the lowest: compound 3; then compounds 2, 1 and 4 (each within the scatter of the next).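

In this assay the steps read a number 5.4 percentage points higher from compound 2 to compound 4 (within the scatter) and a number 4.9 percentage points higher from compound 1 to compound 4 (within the scatter) and so place vinyl level with both longer groups on this saturated chain carbon bound to an oxygen on an aromatic ring. Neither the carboxylic acid of 5-carboxypentyl nor the hydroxyl groups of 1,2-dihydroxyethyl are required for the read-out at this one concentration. Nothing measured here explains this tolerance.

From the compounds shown here alone, whether an amine or a longer chain without a carboxylic acid at the same place holds the read-out stays open. Going by these compounds, whether the effect at this one concentration is stronger or weaker for any of compounds 1, 2 and 4 also stays open: their numbers lie within the scatter of each other.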